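Working notes: the step from compound 3 to compound 4

The source may report more compounds than this note shows. Statements on the series, on what has been measured and on what is new or still open speak of the compounds shown alone.

Measured in a functional assay on HCT-116 cells (Homo sapiens) for antiproliferative activity, read by MTT assay, with a stated time of 24 h; on this read-out lower numbers stand for stronger inhibition and higher numbers for weaker inhibition:
- Compound 1 `COc1cccc(/C=C/C(=O)c2ccc(OC)c3c2OC(C)(C)C=C3)c1`: > 10000 nM, a limit
- Compound 2 `COc1ccc(C(=O)/C=C/c2ccc(Cl)c(Cl)c2)c2c1C=CC(C)(C)O2`: 9440 nM
- Compound 3 `COc1ccc(C(=O)/C=C/c2ccccc2Cl)c2c1C=CC(C)(C)O2`: > 10000 nM, a limit

Compound 3 has no number, only the limit > 10000 nM. The set sits largely at the limit of > 10000 nM in this assay, at which 2 of the 3 values shown sit.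

The next compound is compound 4 `COc1ccc(C(=O)/C=C/c2ccc(O)c(Br)c2)c2c1C=CC(C)(C)O2`, and the change is 3-bromo-4-hydroxyphenyl in place of 2-chlorophenyl on a double-bonded chain carbon bound to a double-bonded chain carbon. It places 3-bromo-4-hydroxyphenyl, a group absent from the measured compounds, on a double-bonded chain carbon bound to a double-bonded chain carbon.

All three measured steps vary this same place. They are an at least 1.0-fold lower number from compound 1 to compound 2 (0.02 log units; that floor lies within the scatter), an at least 1.0-fold higher number from compound 2 to compound 3 (0.02 log units; that floor lies within the scatter) and a step that the two limits leave unreadable from compound 1 to compound 3. None of them shows a change beyond the scatter, so they give no measured size to carry over.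

Within the data shown here, the only number is that of compound 2, at 9440 nM. A reading close to it is the likeliest outcome in this assay. A small move towards a lower number is therefore expected, though a further limit remains quite possible.

The estimated step is an at least 1.4-fold lower number from compound 3 to compound 4 (0.15 log units; that floor lies within the scatter).

For compound 4 the expected value is 7000 nM, with an estimated range of 2000 nM to 15000 nM.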

Compound 4, half-maximal inhibitory concentration: > 10000 nM
Compound 4 was reported as a limit; the forecaster's own chance of this, stated with the estimate: 45%; middle value at least 1.4-fold (0.15 log units) away from the limit.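

In this assay, among these compounds, the only readable new step is an at least 1.0-fold higher number from compound 2 to compound 4 (0.02 log units; that floor lies within the scatter), so 3-bromo-4-hydroxyphenyl, which brings a hydrogen-bond donor that 2-chlorophenyl lacks, shows no measured difference from 3,4-dichlorophenyl on a double-bonded chain carbon bound to a double-bonded chain carbon. The steps to compound 4 from compound 3 and from compound 1 join two limits and cannot be read. This place now carries four different substituted phenyl groups, yet the set still gathers at one reading, with compound 2 the single exception: the limit of > 10000 nM in this assay, at which 3 of the 4 values shown sit.

Whether any group at this place can move the read-out beyond the scatter remains open, since no readable step among the compounds shown does so. Going by these compounds, how a phenyl group bearing an amine or a carboxylic acid would read here is also open, as is whether a change to the shared core, or a longer chain in place of the present one, would give readings that are numbers and not limits.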